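A few compounds are considered here, and "the series" means these few. Any claim that something is new, unique, unknown or untested is made for them only; others in the source may bear on it.

Measured in an ADME assay on L6 cells (Rattus norvegicus) for cytotoxicity, read by resazurin assay, with a stated time of 70 h; on this read-out higher numbers stand for weaker inhibition and lower numbers for stronger inhibition:
- Compound 1 `CC(=O)O[C@@H](C(=O)O)[C@@H](NC(=O)c1ccccc1)c1ccccc1`: > 100000 nM (a limit of the assay)
- Compound 2 `O=C(N[C@@H](c1ccccc1)[C@@H](O)C(=O)OCCCNc1ccnc2cc(Cl)ccc12)c1ccccc1`: "not determined" (no result reported)

Going by these compounds, compound 2 has no number in this assay, so its place on the scale remains open. Among the measured compounds shown here, the only other reading is the one for compound 1, and that is a limit: the limit of > 100000 nM in this assay, at which 1 of the 2 values shown sits.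

Compound 3 `CC(=O)O[C@@H](C(=O)OCCCNc1ccnc2cc(Cl)ccc12)[C@@H](NC(=O)c1ccccc1)c1ccccc1` is the next structure to be tested. The change is acetyl in place of hydrogen on an oxygen on a saturated carbon, with acetyl in place of hydrogen, hydroxy to acetoxy. For the measured compounds named here, no measured step anchors this change, and a shift beyond the usual scatter, in either direction, is not expected. Compound 3 is expected at 20000 nM, with an estimated range of 5000 nM to 80000 nM.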

Compound 3, half-maximal inhibitory concentration: 24200 nM
Compound 3: middle estimate off by 1.2-fold (0.08 log units), on the low side; the measured number falls inside the stated range.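

In this assay, among the compounds shown here, compound 2 carries no number, and no step from it to compound 3 can be read. What hydroxy to acetoxy does on this read-out stays open, and nothing shown bears on the value of compound 3.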